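Hydrazide in place of nitrile on a nitroimidazole thioether

A few compounds are considered here, and "the series" means these few. Any claim that something is new, unique, unknown or untested is made for them only; others in the source may bear on it.

Within the data shown here, in a functional assay on HepG2 cells (Homo sapiens) for cytotoxicity, read by MTT assay, with a stated time of 48 h (on this read-out lower numbers stand for stronger inhibition and higher numbers for weaker inhibition), compound 2 `N#CCSCc1nc2cc([N+](=O)[O-])ccc2[nH]1` gives 30600 nM, the higher of the two numbers known, while compound 1 `O=C(CSCc1nc2cc([N+](=O)[O-])ccc2[nH]1)c1ccc(Cl)cc1` gives 2650 nM, a gap beyond the scatter. Compound 3 `NNC(=O)CSCc1nc2cc([N+](=O)[O-])ccc2[nH]1` is not yet measured in this assay. It differs from compound 2 by aminocarbamoyl in place of cyano on a saturated chain carbon bound to a sulfur. Among the measured compounds shown here, no measured pair shows this change, so the expectation rests on compound 2 alone, and the step from compound 2 to compound 3 is estimated as a 2.0-fold lower number from compound 2 to compound 3 (0.31 log units; beyond the scatter), a modest shift toward a lower number. Compound 3 is therefore expected to give about 15000 nM, between 4000 nM and 60000 nM.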

Compound 3, half-maximal inhibitory concentration: 18600 nM
Compound 3: the middle estimate sits 1.2-fold (0.09 log units) below what was measured; the measured number falls inside the stated range.
By their numbers in this assay, from the lowest: compound 1; then compounds 3 and 2 (each within the scatter of the next).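

In this assay, aminocarbamoyl in place of cyano on a saturated chain carbon bound to a sulfur gives a 1.6-fold lower number from compound 2 to compound 3 (0.22 log units; within the scatter) and so leaves the number within the scatter, even though the entering group carries hydrogen-bond donors and the cyano carries none. On a carbonyl carbon, aminoamino in place of 4-chlorophenyl gives a 7.0-fold higher number from compound 1 to compound 3 (0.85 log units; beyond the scatter), so the change that counts here is the loss of the 4-chlorophenyl of compound 1, not the exchange of cyano. No evidence on the cause of either step is at hand. Going by these compounds, whether a carboxylic acid on this carbon, or a longer chain in place of the (aminocarbamoyl)methyl, would move the number beyond the scatter stays open.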